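A trifluoromethyl group added to compound 2

This account rests on a few compounds, and the source may have more. Where it says the series, first, only, none or still open, it means among the compounds named here.

In an ADME assay on L6 cells (Rattus norvegicus) for cytotoxicity, read by resazurin assay, with a stated time of 70 h (on this read-out higher numbers stand for weaker inhibition and lower numbers for stronger inhibition), compound 1 (`COc1cc(NC(C)CCCNC(=O)Nc2cccc(Cl)c2)c2ncccc2c1`) gives 10 ug/mL as its reading. Compound 2 (`COc1cc(NC(C)CCCNC(=O)NNC(=O)Nc2ccc(Cl)cc2)c2ncccc2c1`) gives 43.3 ug/mL as its reading, the higher of the two numbers, which makes it the weaker inhibitor of the pair. Among the measured compounds shown here, only one measured step connects them: a 4.3-fold higher number from compound 1 to compound 2 (0.64 log units; beyond the scatter) is a modest move, in which ((4-chlorophenyl)carbamoyl)amino replaces 3-chlorophenyl on an amide-type nitrogen.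

Compound 3 (`COc1cc(NC(C)CCCNC(=O)NNC(=O)Nc2ccc(Cl)c(C(F)(F)F)c2)c2ncccc2c1`) keeps compound 2 intact except for one change: trifluoromethyl in place of hydrogen on an aromatic carbon turns 4-chlorophenyl into 4-chloro-3-(trifluoromethyl)phenyl, with the new group ortho to a chloro group. For the measured compounds named here, no measured pair tests this change, so the step from the other part of the molecule offers only a rough sense of scale. With compound 2 at 43.3 ug/mL as the top reading so far, a modest shift towards lower numbers is the cautious expectation, though no shift at all remains possible. The expected move is a 1.5-fold lower number from compound 2 to compound 3 (0.19 log units; within the scatter) on this scale. In this assay compound 3 is expected to read 28 ug/mL within an estimated range of 11 ug/mL to 60 ug/mL on this scale.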

Compound 3, half-maximal inhibitory concentration: 30 ug/mL
Beside the measured number, compound 3's estimate is 1.1-fold (0.03 log units) below it, and the stated range covers the measured number.
By their numbers in this assay, from the lowest: compound 1; then compounds 3 and 2 (each within the scatter of the next).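

Trifluoromethyl in place of hydrogen on this aromatic carbon, ortho to a chloro group and meta to a large group, is a change made on the 4-chlorophenyl group itself, and in this assay it gives a 1.4-fold lower number from compound 2 to compound 3 (0.16 log units; within the scatter) on this read-out. A group of 4 heavy atoms can therefore enter at this position while the two readings stay within the scatter of each other, whereas the earlier step, a 4.3-fold higher number from compound 1 to compound 2 (0.64 log units; beyond the scatter) and beyond the scatter, came from a change elsewhere in the molecule. No measurement offered here explains why the reading responds in this way at this position.

From the compounds shown here alone, whether other groups at this position, such as an amine, a carboxylic acid or a longer chain, would also stay within the scatter remains open, as does the effect of trifluoromethyl on a ring without the chloro group. This single pair also cannot say whether the same addition would give a similar result on compound 1, which carries 3-chlorophenyl and a different link to the ring.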